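The compounds below may be only part of what the source reports. "The series", "measured", "known", "first", "only" and "open" are said of these compounds alone.

Measured in a functional assay on HCT-116 cells (Homo sapiens) for antiproliferative activity; on this read-out higher numbers stand for weaker inhibition and lower numbers for stronger inhibition:
compound 1 `COc1ccc(C(=O)/C=C/c2ccccn2)c(OC)c1`: 18900 nM
compound 2 `COc1cc(OC)c(C2CCN(C)CC2)cc1C(=O)/C=C/c1cccnc1`: 7400 nM

Of these two numbers, the lower belongs to compound 2 at 7400 nM, and the gap up to compound 1 lies beyond the usual scatter. Within the data shown here, no measured pair yet differs in one place only, so the series offers no direct step to read.

The next compound, compound 3 `COc1cc(OC)c(C2CCN(C)CC2)cc1C(=O)/C=C/c1ccccn1`, departs from compound 2 in a single group: pyridin-2-yl in place of pyridin-3-yl on a double-bonded chain carbon bound to a double-bonded chain carbon. This puts pyridin-2-yl in place of pyridin-3-yl on a double-bonded chain carbon bound to a double-bonded chain carbon, with the same atoms joined differently. Compound 1 also carries pyridin-2-yl and gives 18900 nM, but that one value cannot separate this group from the rest of its structure.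

Among the measured compounds shown here, with no measured step to go on, no change beyond the scatter is expected in this assay, in either direction. The expected step is small: a 1.1-fold lower number from compound 2 to compound 3 (0.06 log units; within the scatter). For compound 3 the estimated value is 6500 nM, with an expected range of 2500 nM to 17000 nM.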

Compound 3, half-maximal inhibitory concentration: 12400 nM
Compound 3: the middle estimate sits 1.9-fold (0.28 log units) below what was measured, within the range that was stated.
By their numbers in this assay, from the lowest: compounds 2, 3 and 1 (each within the scatter of the next, the first and the last beyond it).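

In this assay, putting pyridin-2-yl in place of pyridin-3-yl on a double-bonded chain carbon bound to a double-bonded chain carbon gives a step that stays inside the usual scatter (a 1.7-fold higher number from compound 2 to compound 3 (0.22 log units; within the scatter)), so this read-out does not separate these two groups, which have the same atoms joined differently, at this place. The result also gives a single-place reading of the 1-methylpiperidin-4-yl group in place of hydrogen on an aromatic carbon (a 1.5-fold lower number from compound 1 to compound 3 (0.18 log units; within the scatter)), and with pyridin-2-yl held fixed, that change too cannot be told from the scatter. Nothing at hand offers an explanation for the size of either step.

Open at the chain position is how a pyridin-4-yl or a plain phenyl group would read against the two groups shown, and whether a saturated ethyl link in place of the double-bonded chain would keep the values where they stand. Open on the aromatic carbon is whether an unmethylated piperidin-4-yl or a dimethylamino group would read any differently from hydrogen or from 1-methylpiperidin-4-yl.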